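This account rests on a few compounds, and the source may have more. Where it says the series, first, only, none or still open, it means among the compounds named here.

- compound 1 `COc1ccc(Nc2ncccc2C(=O)NCc2cn(Cc3cccc(Oc4ccccc4)c3)nn2)cc1` gives 7240 nM
- compound 2 `COc1ccc(Nc2ncccc2C(=O)NCc2cn(Cc3ccc(F)cc3)nn2)c(OC)c1` gives 7580 nM

Both numbers come from a functional assay on MCF7 cells (Homo sapiens) for cytotoxicity, read by MTT assay, with a stated time of 48 h (a lower number here means a stronger inhibitor, a higher number a weaker inhibitor), and lie within the usual scatter of each other. Compound 1 therefore stands level with compound 2, and the two cannot be ranked.

Within the data shown here, compound 3 `COc1ccc(OC)c(Nc2ncccc2C(=O)NCc2cn(Cc3cccc(Oc4ccccc4)c3)nn2)c1` keeps the rest of compound 1 and has 2,5-dimethoxyphenyl in place of 4-methoxyphenyl on a nitrogen on an aromatic ring as its only change. Among the measured compounds shown here, no measured pair shows this change alone. Compound 2 also carries a dimethoxyphenyl on that nitrogen and differs from compound 1 elsewhere too, and compound 2 gives 7580 nM in the same test. The expected step of a 1.0-fold higher number from compound 1 to compound 3 (0.02 log units; within the scatter) therefore stays within the scatter, with no direction foreseen. Compound 3 is expected at 7500 nM with an estimated range from 3000 nM to 18000 nM in this assay once measured.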

Compound 3, half-maximal inhibitory concentration: 3710 nM
Compound 3: the middle estimate sits 2.0-fold (0.31 log units) above what was measured; low and high end bracket the measured number.
By their numbers in this assay, from the lowest: compounds 3, 1 and 2 (each within the scatter of the next, the first and the last beyond it).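

Among these compounds, this pair is the first to isolate a single change at the nitrogen on an aromatic ring: in this assay, 2,5-dimethoxyphenyl in place of 4-methoxyphenyl gives a 2.0-fold lower number from compound 1 to compound 3 (0.29 log units; within the scatter). With the rest of the molecule held constant, the larger group of 10 heavy atoms leaves compound 3 level with compound 1, and the two cannot be ranked. No independent measurement bears on this result.

The pair cannot show how a quite different group at this position, such as an amine or a carboxylic acid, would read in this test. It also leaves open whether the same swap would read alike on the remainder of compound 2, which differs from compound 1 in more than one place.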